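The compounds below may be only part of what the source reports. "The series", "measured", "known", "first", "only" and "open" are said of these compounds alone.

Going by the values given here, compound 2, `CCCn1c(SCc2cc([N+](=O)[O-])ccc2OC)nc2cc(NC(=O)NC(C)(C)C)cc(C(=O)OC)c21`, is the stronger of the two compounds measured so far. In an assay on isolated protein for inhibition of Gonadotropin-releasing hormone receptor (Homo sapiens) (a higher number here means a weaker inhibitor, a lower number a stronger inhibitor), compound 2 gives 37 nM. Its only measured companion, compound 1, `COc1ccc([N+](=O)[O-])cc1CSc1nc2cc(NC(=O)C3CCC3)ccc2n1C(C)C`, gives 1500 nM in this assay, a gap that lies well beyond the usual scatter; the two compounds differ in several places at once, so nothing is learned here about any single change.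

Compound 3, `CCCn1c(SCc2cc([N+](=O)[O-])ccc2OC)nc2cc(NC(=O)NC(C)(C)C)cc(C(=O)NCCCN(C)C)c21`, has not been measured. It differs from compound 2 in one place: (3-(dimethylamino)propyl)amino in place of methoxy on a carbonyl carbon. The carbonyl group and everything else in the molecule stay as they are. Among the compounds with values here, no pair of measured compounds shows this change, so there is no measured step to lean on, and the expectation rests on compound 2 alone.

The step from compound 2 to compound 3 is expected to be small, no larger than the scatter in either direction, at about a 1.2-fold higher number from compound 2 to compound 3 (0.09 log units; within the scatter). Compound 3 is therefore estimated at 45 nM in this assay, with a likely range from 12 nM to 170 nM.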

Compound 3, half-maximal inhibitory concentration: 170 nM
Compound 3: middle estimate off by 3.8-fold (0.58 log units), on the low side; the measured number falls inside the stated range.
By their numbers in this assay, from the lowest: compound 2; then compound 3; then compound 1.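

In this assay, putting (3-(dimethylamino)propyl)amino in place of methoxy on this carbonyl carbon gives a 4.6-fold higher number from compound 2 to compound 3 (0.66 log units; beyond the scatter), the only step shown between compounds that differ in one place. This position therefore responds to what is attached there, and the change costs some inhibition, though the step is modest for a swap of 2 heavy atoms for 7. No supporting data bear on why the number rises.

The swap from methoxycarbonyl to (3-(dimethylamino)propyl)carbamoyl changes the atom on the carbonyl, the chain length and the chain end all at once, so the compounds shown cannot separate these. A simple methylamide, a carboxylic acid, or a shorter or longer chain ending in dimethylamino on this carbonyl carbon would show which part carries the step.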